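The compounds below may be only part of what the source reports. "The series", "measured", "known", "first", "only" and "open" are said of these compounds alone.

Measured so far:
- compound 1 `C=CC1=C(C(=O)NCCC)C(c2ccc(Cl)c(Cl)c2)OC1` — > 100000 nM
- compound 2 `C=CC1=C(C(=O)NC(C)(C)C)C(c2ccc(F)cc2)OC1` — > 100000 nM

In a functional assay on A549 cells (Homo sapiens) for cytotoxicity, read by MTT assay, with a stated time of 24 h (on this read-out lower numbers stand for stronger inhibition and higher numbers for weaker inhibition), compound 1 gives only a limit, > 100000 nM, and no number. Compound 2 likewise gives only a limit in this assay, > 100000 nM. Both readings sit at the limit of > 100000 nM in this assay, at which 2 of the 2 values shown sit, so compound 1 stands at the edge of what this assay reports. Compound 3 `C=CC1=C(C(=O)NCc2ccccc2)C(c2ccc(Cl)c(Cl)c2)OC1` differs from compound 1 by phenyl in place of ethyl on a saturated chain carbon bound to an amide-type nitrogen. The step that the limit leaves unreadable from compound 1 to compound 3 is expected to be none beyond the scatter. Compound 3 is therefore expected to give 150000 nM in this assay, within a range of 30000 nM to 500000 nM, most likely again as a limit rather than a number.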

Compound 3, half-maximal inhibitory concentration: > 100000 nM
Compound 3 gave a limit, no number; the forecaster's own chance of this, stated with the estimate: 80%; the middle value is on the limit's open side.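

Among the compounds shown here, compound 1 and compound 3 both give only a limit in this assay and no number, so no step between them can be read. The compounds shown leave open whether any amide group on the shared core gives a number at all.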